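Carboxymethyl for sec-butyl in an amide side chain

The source may hold more compounds than are shown below. What is called first, only, known or untested is meant among the compounds shown, and "the series" means these compounds.

Compound 1 `CCn1c(C(=O)Nc2cccc(C(F)(F)F)c2)ccc1C(CC)(CC)c1ccc(OCCC(O)(CC)CC)c(C)c1` gives 5900 nM in an assay on cells for agonist activity at vitamin D3 receptor (Homo sapiens), with a stated time of 96 h; a higher number here means that more compound is needed for the effect, a lower number that less compound is needed. Compound 2 `CCC(C)C(NC(=O)c1ccc(C(CC)(CC)c2ccc(OCCC(O)(CC)CC)c(C)c2)n1CC)C(=O)OC` reaches only the limit of > 10000 nM in this assay, a limit and not a number (the limit of > 10000 nM in this assay, at which 1 of the 2 values shown sits). The step of an at least 1.6-fold higher number from compound 1 to compound 2 (0.22 log units; that floor lies within the scatter) concerns the group on the amide-type nitrogen. Compound 3 `CCn1c(C(=O)NC(CC(=O)O)C(=O)OC)ccc1C(CC)(CC)c1ccc(OCCC(O)(CC)CC)c(C)c1` differs from compound 2 by carboxymethyl in place of sec-butyl on a saturated chain carbon bound to an amide-type nitrogen and a carbonyl carbon. Among the measured compounds shown here, no measured step touches that chain carbon, so no size of change in this assay beyond the scatter can be inferred, and compound 3 is expected to remain near the limit. Compound 3 is estimated at 15000 nM in this assay, within 5000 nM to 50000 nM, the expected step being a step that the limit leaves unreadable from compound 2 to compound 3.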

Compound 3, half-maximal effective concentration: 26 nM
For compound 3 the middle estimate is 580-fold (2.76 log units) above the measured one; measured number below the stated range.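

In this assay, carboxymethyl in place of sec-butyl on this saturated chain carbon gives an at least 380-fold lower number from compound 2 to compound 3 (2.58 log units; beyond the scatter), the first sign that the number depends heavily on what this carbon carries. That step is only a floor, because compound 2 stands at a limit and not a number: the limit of > 10000 nM in this assay, at which 1 of the 3 values shown sits. The group on the amide-type nitrogen as a whole also counts, with a 230-fold lower number from compound 1 to compound 3 (2.36 log units; beyond the scatter). Still open, from the compounds shown here alone, is whether a longer chain ending in a carboxylic acid, or an amine, would serve at this carbon as carboxymethyl does. Going by these compounds, the part played by the methyl ester also stays open.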